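The source may report more compounds than this note shows. Statements on the series, on what has been measured and on what is new or still open speak of the compounds shown alone.

Working notes on the series. All members share one core and differ only at a saturated chain carbon bound to a double-bonded chain carbon and an oxygen next to a carbonyl group. Compound 1 `C=C(C(=O)c1ccc(OC)cc1)C(OC(=O)c1ccccc1)c1ccccc1F` gives 73700 nM in a functional assay on A549 cells (Homo sapiens) for inhibition, read by XTT assay, with a stated time of 48 h; a higher number here means a weaker inhibitor, a lower number a stronger inhibitor. Compound 2 `C=C(C(=O)c1ccc(OC)cc1)C(OC(=O)c1ccccc1)c1ccc(Cl)cc1Cl` gives 79200 nM. Compound 3 `C=C(C(=O)c1ccc(OC)cc1)C(OC(=O)c1ccccc1)C1CCCCC1` gives 62100 nM. Every step among these three sits within the scatter: a 1.1-fold higher number from compound 1 to compound 2 (0.03 log units; within the scatter), a 1.2-fold lower number from compound 1 to compound 3 (0.07 log units; within the scatter) and a 1.3-fold lower number from compound 2 to compound 3 (0.11 log units; within the scatter). Compound 3 thus carries the smallest of the three numbers shown, yet it is within the scatter of compound 1, its nearest neighbour, and of compound 2, its furthest, so the three are not separated.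

Compound 4 `C=C(C(=O)c1ccc(OC)cc1)C(OC(=O)c1ccccc1)c1ccccc1[N+](=O)[O-]` is not yet measured. Its change from compound 3 is 2-nitrophenyl in place of cyclohexyl on a saturated chain carbon bound to a double-bonded chain carbon and an oxygen next to a carbonyl group. Among the compounds with values here, the steps that bear on it are the two that exchange an aromatic substituent for cyclohexyl at this place, a 1.2-fold lower number from compound 1 to compound 3 (0.07 log units; within the scatter) and a 1.3-fold lower number from compound 2 to compound 3 (0.11 log units; within the scatter), and the one between 2-fluorophenyl and 2,4-dichlorophenyl, a 1.1-fold higher number from compound 1 to compound 2 (0.03 log units; within the scatter); none moved beyond the scatter. Replacing cyclohexyl by 2-nitrophenyl is therefore expected to give a step of no size beyond the scatter in this assay, namely a 1.1-fold higher number from compound 3 to compound 4 (0.05 log units; within the scatter). Compound 4 is estimated at 70000 nM, with a range from 35000 nM to 140000 nM.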

Compound 4, half-maximal inhibitory concentration: 45500 nM
Compound 4: middle estimate off by 1.5-fold (0.19 log units), on the high side; low and high end bracket the measured number.
By their numbers in this assay, from the lowest: compounds 4, 3, 1 and 2 (each within the scatter of the next).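

Within the data shown here, exchanging cyclohexyl for 2-nitrophenyl at this place, on a saturated chain carbon bound to a double-bonded chain carbon and an oxygen next to a carbonyl group, leaves the result in this assay unresolved from the earlier compounds (a 1.4-fold lower number from compound 3 to compound 4 (0.14 log units; within the scatter)), and the same holds against the dichlorinated analogue (a 1.7-fold lower number from compound 2 to compound 4 (0.24 log units; within the scatter)). Among these compounds, the one step that stays on the same aromatic ring, nitro in place of fluoro on an aromatic carbon, also fails to separate the pair (a 1.6-fold lower number from compound 1 to compound 4 (0.21 log units; within the scatter)), so a substituent with hydrogen-bond acceptors now joins halogenated phenyl and cyclohexyl groups at this place without any member of these four standing apart. No measurement is available that would account for these values or for the absence of a separation.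

On these data alone, whether any group at this place can move the number beyond the scatter remains open, for example an amine, a carboxylic acid, a hydroxyl or a longer chain such as n-hexyl. The compounds shown also leave open how the number responds to changes elsewhere on the shared core, since all four differ at this one place only.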